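The source may hold more compounds than are shown below. What is called first, only, known or untested is meant among the compounds shown, and "the series" means these compounds.

Compound 1 `CCCCCCCCCCCCCCc1ccccc1C(SCCC(=O)O)SCCC(=O)O` gives 1250 nM in an assay on membranes from lung (Cavia porcellus) for binding affinity to cysteinyl leukotriene receptor (Homo sapiens); on this read-out higher numbers stand for weaker inhibition and lower numbers for stronger inhibition. Compound 2 `CCCCc1ccccc1C(SCCC(=O)O)SCCC(=O)O` reaches only the limit of this assay, > 20000 nM. Compound 3 `CCCCC/C=C/C/C=C/COc1ccccc1C(SCCC(=O)O)SCCC(=O)O` gives 1000 nM.

Compound 3 has the lowest number of the two given as numbers, though its gap to compound 1 lies within the scatter. Compound 4 `CCOCCOCCOCCOc1ccccc1C(SCCC(=O)O)SCCC(=O)O` differs from it by (2-(2-ethoxyethoxy)ethoxy)methyl in place of deca-1,4-dien-1-yl on a saturated chain carbon bound to an oxygen on an aromatic ring. Going by the values given here, the one measured step, an at least 16-fold higher number from compound 1 to compound 2 (1.20 log units; beyond the scatter), shows that losing most of the chain on the core costs heavily, with compound 2 at the limit of > 20000 nM in this assay, at which 1 of the 3 values shown sits. The change to compound 4 keeps the chain length but swaps its atoms, so a moderately higher number is expected, a 5.0-fold higher number from compound 3 to compound 4 (0.70 log units; beyond the scatter). Compound 4 is therefore estimated at 5000 nM, between 1500 nM and 20000 nM.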

Compound 4, inhibition constant: > 20000 nM
Compound 4: no number, only a limit; the forecaster's own chance of this, stated with the estimate: 30%; middle value at least 4.0-fold (0.60 log units) from the limit.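

The side chain on the shared core matters through more than its size: (2-(2-ethoxyethoxy)ethoxy)methyl carries 10 heavy atoms, as deca-1,4-dien-1-yl does, yet the exchange gives an at least 20-fold higher number from compound 3 to compound 4 (1.30 log units; beyond the scatter). Before this, only the loss of most of the chain had shown a cost of this size. Compound 4 gives a limit and not a number, as compound 2 does: the limit of > 20000 nM in this assay, at which 2 of the 4 values shown sit.

On these data alone, how far compound 4 lies past that limit stays open. So does whether a chain holding an amine or a carboxylic acid would behave like this one.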